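Adding a Butyl Group to a Series at the Limit

A few compounds are considered here, and "the series" means these few. Any claim that something is new, unique, unknown or untested is made for them only; others in the source may bear on it.

Measured compounds:
- compound 1, `NS(=O)(=O)NCC1CCN(c2cc(-c3ccccc3)ncn2)CC1`, in a functional assay on M21 cells (Homo sapiens) for antiproliferative activity, read by sulforhodamine B assay, with a stated time of 48 h; a lower number here means a stronger inhibitor of growth, a higher number a weaker inhibitor of growth: > 100000 nM, a limit of the assay
- compound 2, `COc1ccccc1-c1cc(N2CCC(CNS(N)(=O)=O)CC2)ncn1`, in this assay: > 100000 nM, a limit of the assay
- compound 3, `NS(=O)(=O)NCCC1CCN(c2cc(-c3ccccc3)ncn2)CC1`, in this assay: > 100000 nM, a limit of the assay

Compound 3 sits at the limit of the assay, as shown by the limit of > 100000 nM in this assay, at which 3 of the 3 values shown sit. The two measured steps, a step that the two limits leave unreadable from compound 1 to compound 2 and a step that the two limits leave unreadable from compound 1 to compound 3, both run between limits, so neither gives a readable size.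

Compound 4, `CCCCc1ccc(-c2cc(N3CCC(CCNS(N)(=O)=O)CC3)ncn2)cc1`, differs from compound 3 by butyl in place of hydrogen on an aromatic carbon. Within the data shown here, no measured step touches this kind of change, and the steps that do exist are unreadable, so the data give no footing for a direction in this assay. With every value in the series at the limit, the plainest expectation is that compound 4 also stays near it; the estimated step of a number no higher from compound 3 to compound 4 (the limit leaves the size open) is therefore set close to none, with a wide range. Compound 4 is expected to give about 100000 nM in this assay, between 5000 nM and 300000 nM, and it may well return only a limit again.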

Compound 4, concentration for 50% growth inhibition: 15100 nM
For compound 4 the middle estimate is 6.6-fold (0.82 log units) above the measured one; low and high end bracket the measured number.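

Among these compounds, the earlier steps cannot be read, so this is the first change with a visible direction: in this assay, butyl in place of hydrogen on an aromatic carbon, para to a large group, gives an at least 6.6-fold lower number from compound 3 to compound 4 (0.82 log units; beyond the scatter). This ring position can therefore carry a change that moves the number off the limit, and compound 4 alone among the compounds shown has a readable value. The step has a floor but no upper end, because one of its two ends is a limit: the limit of > 100000 nM in this assay, at which 3 of the 4 values shown sit.

Going by these compounds, it stays open whether a shorter chain such as ethyl, a longer chain such as hexyl, or an amine at the same place would lower the number as well. On these data alone, it also stays open whether butyl would act in the same way on compound 1, with its shorter link to the sulfamoylamino group.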